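Phenyl to 3-methylphenyl: what to expect of compound 3

This account rests on a few compounds, and the source may have more. Where it says the series, first, only, none or still open, it means among the compounds named here.

- compound 1 `O=C(NO)c1ccc(NCc2nc(-c3ccc(F)cc3)nn2-c2ccccc2)cc1`: 8960 nM
- compound 2 `O=C(NO)c1ccc(NCc2nc(-c3ccccc3)nn2-c2ccccc2)cc1`: 17700 nM

In a functional assay on MGC-803 cells (Homo sapiens) for antiproliferative activity, read by MTT assay, with a stated time of 72 h (on this read-out lower numbers stand for stronger inhibition and higher numbers for weaker inhibition), compound 2 gives 17700 nM, within the scatter of compound 1, so the two cannot be ranked. Compound 3 `Cc1cccc(-c2nc(CNc3ccc(C(=O)NO)cc3)n(-c3ccccc3)n2)c1` differs from compound 2 by methyl in place of hydrogen on an aromatic carbon. This is methyl in place of hydrogen on an aromatic carbon, phenyl to 3-methylphenyl.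

Among the measured compounds shown here, only one measured step bears on this change: a 2.0-fold higher number from compound 1 to compound 2 (0.30 log units; within the scatter), with hydrogen in place of fluoro on an aromatic carbon. For the measured compounds named here, it involves a different group, and no methyl analogue has been measured, so it is only a weak guide. On this evidence, no step beyond the scatter is expected in this assay, in either direction. The estimated step is a 1.3-fold lower number from compound 2 to compound 3 (0.10 log units; within the scatter). For compound 3 the estimated value is 14000 nM, with an expected range from 6500 nM to 30000 nM.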

Compound 3, half-maximal inhibitory concentration: 8710 nM
Compound 3: the middle estimate sits 1.6-fold (0.21 log units) above what was measured, and the stated range covers the measured number.
By their numbers in this assay, from the lowest: compounds 3, 1 and 2 (each within the scatter of the next, the first and the last beyond it).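

Methyl in place of hydrogen on this aromatic carbon gives a 2.0-fold lower number from compound 2 to compound 3 (0.31 log units; beyond the scatter) in this assay and is the first step in the series to lie beyond the scatter, though it is a modest one. The comparison of 3-methylphenyl with 4-fluorophenyl gives a 1.0-fold lower number from compound 1 to compound 3 (0.01 log units; within the scatter), so these two substituted rings cannot be ranked, and of the two compounds only compound 3 stands apart from the phenyl of compound 2. Nothing at hand gives a reason for the step from hydrogen to methyl.

Open questions remain as to whether a methoxy group, an amine or a carboxylic acid at the same place would move the number further, or in the opposite direction. As far as these compounds go, it also remains open whether a longer chain, such as ethyl, would keep the modest step seen with methyl.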